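This account rests on a few compounds, and the source may have more. Where it says the series, first, only, none or still open, it means among the compounds named here.

Working notes on the series. In a functional assay on MCF7 cells (Homo sapiens) for antiproliferative activity, read by MTT assay, with a stated time of 72 h (a lower number here means a stronger inhibitor, a higher number a weaker inhibitor), compound 1 `COc1ccc(N2CCN(C(=S)SCc3ccc4nc(N)nc(N)c4c3)CC2)cc1` gives 1580 nM, compound 2 `Nc1nc(N)c2cc(CSC(=S)N3CCN(c4ccc(F)cc4F)CC3)ccc2n1` gives 3670 nM and compound 3 `Nc1nc(N)c2cc(CSC(=S)N3CCN(c4ccc([N+](=O)[O-])cc4)CC3)ccc2n1` gives 1470 nM. Compound 3 thus stands level with compound 1 and clear of compound 2. Of the measured steps, a 1.1-fold lower number from compound 1 to compound 3 (0.03 log units; within the scatter) stays within the scatter, whereas a 2.3-fold higher number from compound 1 to compound 2 (0.37 log units; beyond the scatter) and a 2.5-fold lower number from compound 2 to compound 3 (0.40 log units; beyond the scatter) are modest.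

The next change is made at the same place. Compound 4 `Nc1nc(N)c2cc(CSC(=S)N3CCN(c4ncccn4)CC3)ccc2n1` carries pyrimidin-2-yl in place of 4-nitrophenyl on an amine nitrogen in a ring. Among the compounds with values here, no measured compound has a ring with hetero atoms in that place, so the three steps above offer only a guide to size, not a direct precedent. All three changes at this place stayed modest or smaller, so a step of that size is expected here too. Within the data shown here, a small rise in this assay is expected, or none beyond the scatter, since the only clear departure from compound 3 lies upward, in compound 2 at 3670 nM. The expected change is a 1.5-fold higher number from compound 3 to compound 4 (0.18 log units; within the scatter). Compound 4 is estimated at 2200 nM, with an expected range of 900 nM to 5500 nM.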

Compound 4, half-maximal inhibitory concentration: 4190 nM
Estimate against measurement, compound 4: 1.9-fold (0.28 log units) below, and the stated range covers the measured number.
By their numbers in this assay, from the lowest: compounds 3 and 1 (each within the scatter of the next); then compounds 2 and 4 (each within the scatter of the next).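

In this assay, within the data shown here, pyrimidin-2-yl is the first ring with hetero atoms on this amine nitrogen. Exchanging 4-nitrophenyl for it gives a 2.9-fold higher number from compound 3 to compound 4 (0.45 log units; beyond the scatter), and exchanging 4-methoxyphenyl for it gives a 2.7-fold higher number from compound 1 to compound 4 (0.42 log units; beyond the scatter), so the loss is real but stays modest. Exchanging 2,4-difluorophenyl for it gives a 1.1-fold higher number from compound 2 to compound 4 (0.06 log units; within the scatter), which places the four compounds in two groups, compounds 1 and 3 with the lower numbers and compounds 2 and 4 with the higher, so a ring with hetero atoms here does not open a new level of its own. (Nothing measured in this set accounts for this split).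

With one ring with hetero atoms and three substituted phenyl rings, the compounds shown leave open whether the higher numbers of compounds 2 and 4 have anything in common or arrive by separate routes. Also open, as far as these compounds go, is how the number responds to an unsubstituted phenyl, a pyridin-2-yl or a benzyl on this nitrogen, and whether a non-aromatic group such as cyclohexyl is tolerated there.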